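Polyacetylene enol isomers and cytotoxicity on ovarian cancer cells

The source may hold more compounds than are shown below. What is called first, only, known or untested is meant among the compounds shown, and "the series" means these compounds.

The compounds measured so far:
compound 1, `CCCCCCCC#CC#CCO`, 4.63 ug/mL
compound 2, `C=CCCCCCC#CC#C/C(O)=C\C(C)=O`, 3.52 ug/mL
compound 3, `C=CCCCCCC#CC#CCOCCO`, 17.9 ug/mL

In a functional assay on SK-OV-3 cells (Homo sapiens) for cytotoxicity (a higher number here means that more compound is needed for the effect, a lower number that less compound is needed), compound 2 gives 3.52 ug/mL, the lowest number of the three. Its nearest neighbour is compound 1, which in this assay gives 4.63 ug/mL; this difference is within the scatter, so no order between compound 2 and compound 1 can be read from the numbers. Compound 3, which in this assay gives 17.9 ug/mL, stands beyond the scatter from compound 2, so compound 3 needs more compound for the same effect than compound 2 does.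

The account now moves from compound 2 to compound 4, `C=CCCCCCC#CC#C/C(O)=C/C(C)=O`, which has not yet been measured. The difference between the two is the two compounds have the same atoms and bonds and differ only in configuration as drawn: 1 of 1 stereo elements differ; a double bond is drawn E in compound 2 and Z in compound 4. Nothing else in the structures is altered.

Among the compounds with values here, no measured pair in this set differs only in configuration at a double bond, so there is no step to lean on. With the atoms and bonds unchanged, the expectation for compound 4 is a step of no size beyond the scatter, in either direction, and the expected step is a 1.1-fold higher number from compound 2 to compound 4 (0.06 log units; within the scatter). Compound 4 is therefore estimated to give 4 ug/mL in this assay, with a range from 1.8 ug/mL to 9 ug/mL.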

Compound 4, concentration for half-maximal effect: 5.23 ug/mL
The estimate for compound 4 lay 1.3-fold (0.12 log units) below the measured number, and the stated range covers the measured number.
By their numbers in this assay, from the lowest: compounds 2, 1 and 4 (each within the scatter of the next); then compound 3.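

In this assay, the change of the double bond from E to Z gives a 1.5-fold higher number from compound 2 to compound 4 (0.17 log units; within the scatter), so no order between the two isomers can be read from their numbers. Within the data shown here, this is the first step in the set that links two compounds differing in one place, and nothing else can stand behind it: the fact that compounds 2 and 4 differ only in the configuration as drawn At this double bond, then, the configuration as drawn does not separate the two compounds in this assay, and for the purposes of this assay the E and Z forms stand at one level.

Whether a carboxylic acid or an amine in place of the enol and its ketone would move the number beyond the scatter stays open, as no compound shown carries such a group. Also open, as far as these compounds go, is whether a longer chain would shift the number for either isomer, and the gap between these two compounds and compound 3 cannot be tied to any single change, as compound 3 differs from them in more than one place.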